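Ring swap on the sulfur of the shared core

A few compounds are considered here, and "the series" means these few. Any claim that something is new, unique, unknown or untested is made for them only; others in the source may bear on it.

Compound 1 `CC(C)[C@H](NC(=O)COc1cccc2ccccc12)C(=O)N[C@@H](CC(=O)O)C(=O)CSc1nc(-c2ccccc2)no1`: 102000 nM
Compound 2 `CC(C)[C@H](NC(=O)COc1cccc2ccccc12)C(=O)N[C@@H](CC(=O)O)C(=O)CSc1nnnn1C`: > 200000 nM

Among the compounds with values here, in a functional assay on Jurkat cells (Homo sapiens) for inhibition (on this read-out lower numbers stand for stronger inhibition and higher numbers for weaker inhibition), compound 1 gives 102000 nM, the only numeric value shown. Compound 2 sits at an assay limit, > 200000 nM. Within the data shown here, the single measured step, an at least 1.9-fold higher number from compound 1 to compound 2 (0.29 log units; that floor lies within the scatter), runs toward weaker inhibition and ends at the limit of > 200000 nM in this assay, at which 1 of the 2 values shown sits. Compound 3 `CC(C)[C@H](NC(=O)COc1cccc2ccccc12)C(=O)N[C@@H](CC(=O)O)C(=O)CSc1nccc(C(F)(F)F)n1` carries 4-(trifluoromethyl)pyrimidin-2-yl in place of 3-phenyl-1,2,4-oxadiazol-5-yl on a sulfur. Among the measured compounds shown here, no measured step covers a six-membered ring with two hetero atoms on that sulfur; the step to compound 2 bears on it only as another ring replacement there. A step of about a 1.5-fold higher number from compound 1 to compound 3 (0.17 log units; within the scatter) is expected, toward weaker inhibition, near the scatter. Compound 3 is expected to give 150000 nM, between 50000 nM and 400000 nM.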

Compound 3, half-maximal inhibitory concentration: > 200000 nM
Compound 3 gave a limit, no number; the forecaster's own chance of this, stated with the estimate: 35%; middle value at least 1.3-fold (0.12 log units) from the limit.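

Compound 3, with a six-membered ring with two hetero atoms on the sulfur, gives > 200000 nM in this assay, which is a limit and not a number. The swap gives an at least 1.9-fold higher number from compound 1 to compound 3 (0.29 log units; that floor lies within the scatter), so this second ring replacement also shows no loss beyond the scatter. The step between the other two compounds cannot be read, and the read-out offers no room to rank them: the limit of > 200000 nM in this assay, at which 2 of the 3 values shown sit.

Going by these compounds, whether any group on that sulfur gives clearly stronger inhibition than compound 1 stays open. So does the effect of an amine or a longer carbon chain there.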